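The compounds below may be only part of what the source reports. "The series", "measured", "known", "first", "only" and "open" are said of these compounds alone.

Of the compounds shown here, three built on a shared core have been measured in an assay on CHO cells with Alpha-2C adrenergic receptor (Homo sapiens) as the target; on this read-out lower numbers stand for smaller maximal responses and higher numbers for larger maximal responses. Compound 1 `C=CCc1cccc(CC=C)c1OC(C)C1=NCCN1` gives 0.9, compound 2 `CC(Oc1ccccc1OC1CC1)C1=NCCN1` gives 0.7, and compound 3 `CC(=O)c1ccccc1OC(C)C1=NCCN1` gives 0.65. Compound 2 stands second highest of the three: its nearest neighbour is compound 3, whose number lies within the scatter of that of compound 2, while compound 1 lies beyond the scatter above it.

Compound 4 `CC(Oc1ccccc1S(C)(=O)=O)C1=NCCN1` differs from compound 2 in a single place: methylsulfonyl in place of cyclopropyloxy on an aromatic carbon. Going by the values given here, one measured step bears on this change, the one in which acetyl takes the place of cyclopropyloxy on the same aromatic carbon, which gave a number 0.050 lower from compound 2 to compound 3 (within the scatter). Among the compounds with values here, that step stayed within the scatter, so on the single precedent available, exchanging the cyclopropyloxy for another group at this place has moved the maximal response little. On that ground the expected step is a number 0.050 lower from compound 2 to compound 4 (within the scatter), which is expected to remain within the scatter. The number estimated for compound 4 is 0.65, with a range from 0.45 to 0.85.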

Compound 4, intrinsic activity: the largest response reached, as a fraction of the reference agonist's: 0.6
Beside the measured number, compound 4's estimate is 0.050 above it, and the stated range covers the measured number.
By their numbers in this assay, from the lowest: compounds 4, 3 and 2 (each within the scatter of the next); then compound 1.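

In this assay, a second replacement at this aromatic carbon also stays within the scatter: a number 0.10 lower from compound 2 to compound 4 (within the scatter) when methylsulfonyl takes the place of cyclopropyloxy, and a number 0.050 lower from compound 3 to compound 4 (within the scatter) when methylsulfonyl takes the place of acetyl. Where one step stood before, cyclopropyloxy, acetyl and methylsulfonyl now form a set of three groups whose maximal responses cannot be told apart, and the loss of the three-membered ring on going to methylsulfonyl leaves the response within the scatter as well. Nothing at hand gives a reason for this sameness.

The compounds shown leave open whether an amine or a carboxylic acid on this aromatic carbon would also stay within the scatter. They also leave open whether a longer chain there would do the same.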